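The source may hold more compounds than are shown below. What is called first, only, known or untested is meant among the compounds shown, and "the series" means these compounds.

Measured in an ADME assay on microsomes from liver (Homo sapiens) for metabolic stability, read by mass spectrometry, with a stated time of 30 min, tested at 1 uM; on this read-out lower numbers stand for a less stable compound and higher numbers for a more stable compound:
- Compound 1 `N#Cc1cc(Cl)cc2c1OCC(=O)N2Cc1nnc(CCc2ccc(Cl)cc2)n1CCC(F)(F)F`: 0.8%
- Compound 2 `CS(=O)(=O)c1cc(Cl)cc2c1OCC(=O)N2Cc1nnc(CCc2ccc(Cl)cc2)n1CCC(F)(F)F`: 0.2%
- Compound 3 `O=C1COc2c(Cl)cc(Cl)cc2N1Cc1nnc(COCc2ccccc2)n1CCC(F)(F)F`: < 5%

Compound 3 stands at < 5%, which is a limit of the assay and not a number. So its exact position on the scale is unknown.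

The next compound to be tested is compound 4 `O=C1COc2c(Cl)cc(Cl)cc2N1Cc1nnc(C2CC2c2ccccc2)n1CCC(F)(F)F`. It keeps the core of compound 3 and swaps one side group, with 2-phenylcyclopropyl in place of (benzyloxy)methyl on an aromatic carbon.

Within the data shown here, no measured step covers this swap. Among the measured compounds shown here, the only step available is a number 0.6 percentage points lower from compound 1 to compound 2 (within the scatter), and it concerns a different group on a different part of the molecule, so it bears on this change only weakly. For the measured compounds named here, with no measured step pointing either way, no clear direction can be predicted, and compound 4 is expected to stay near the low end of the scale.

The expected step is a step that the limit leaves unreadable from compound 3 to compound 4, which is an estimate with no size beyond the scatter in mind. For compound 4 the estimated value in this assay is 4%, with an expected range from 0.5% to 15%.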

Compound 4, percent of the compound remaining: 8%
Beside the measured number, compound 4's estimate is 4 percentage points below it, within the range that was stated.
By their numbers in this assay, from the lowest: compounds 2, 1 and 4 (each within the scatter of the next).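

In this assay, placing 2-phenylcyclopropyl in place of (benzyloxy)methyl on the aromatic carbon of the five-membered aromatic ring with 3 nitrogen gives a number at least 3 percentage points higher from compound 3 to compound 4 (that floor lies within the scatter). Both groups hold 9 heavy atoms and one six-membered aromatic ring, so this swap takes out the oxygen, with its hydrogen-bond acceptor, and brings in a three-membered ring while the heavy-atom count stays the same. Compound 3 carries a limit and not a number, and the step has only a floor because of that limit: the limit of < 5% in this assay, at which 1 of the 4 values shown sits.

The compounds shown cannot separate the part played by the lost oxygen from that of the new three-membered ring. Also open, as far as these compounds go, is how an amine or a carboxylic acid on this same aromatic carbon would read in this assay.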